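Methoxy to Chloro Swap and a Predicted Cytotoxicity Value

A few compounds are considered here, and "the series" means these few. Any claim that something is new, unique, unknown or untested is made for them only; others in the source may bear on it.

Three compounds have been measured:
compound 1, `COc1cccc(N2CCN(CC(=O)N3CCN(c4nnc(-c5ccc(C)cc5)c(-c5ccc(C)cc5)n4)CC3)CC2)c1`, 867000 nM
compound 2, `Cc1ccc(-c2nnc(N3CCN(C(=O)CN4CCN(c5cccc(Cl)c5)CC4)CC3)nc2-c2ccc(C)cc2)cc1`, 797000 nM
compound 3, `COc1ccccc1N1CCN(CC(=O)N2CCN(c3nnc(-c4ccc(Cl)cc4)c(-c4ccc(Cl)cc4)n3)CC2)CC1`, 330000 nM

These numbers come from a functional assay on MCF7 cells (Homo sapiens) for cytotoxicity, read by MTT assay, with a stated time of 24 h; on this read-out lower numbers stand for stronger inhibition and higher numbers for weaker inhibition. Compound 1 and compound 2 differ in one place, (chloro in place of methoxy on an aromatic carbon), and that change gave a 1.1-fold lower number from compound 1 to compound 2 (0.04 log units; within the scatter). Compound 3 has a different core; the difference between the cores of compound 1 and compound 3 is not broken down here. Compound 3 shows the lowest number of the three. Compound 4, `O=C(CN1CCN(c2ccccc2Cl)CC1)N1CCN(c2nnc(-c3ccc(Cl)cc3)c(-c3ccc(Cl)cc3)n2)CC1`, is not yet measured and differs from compound 3 by chloro in place of methoxy on an aromatic carbon. This is the same kind of change as from compound 1 to compound 2, but not the same: in compound 4 the chloro sits ortho to a large group, in compound 2 meta to a large group. Because the earlier step of a 1.1-fold lower number from compound 1 to compound 2 (0.04 log units; within the scatter) stayed within the scatter, a similarly small step is expected, a 1.1-fold lower number from compound 3 to compound 4 (0.04 log units; within the scatter). In this assay compound 4 is estimated at 300000 nM, between 120000 nM and 750000 nM.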

Compound 4, half-maximal inhibitory concentration: 396000 nM
Estimate against measurement, compound 4: 1.3-fold (0.12 log units) below, and the stated range covers the measured number.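

In this assay, putting chloro in place of methoxy again changed little, giving a 1.2-fold higher number from compound 3 to compound 4 (0.08 log units; within the scatter). The change behaved alike on the two cores: the same change on two cores in this assay, a 1.1-fold lower number (0.04 log units; within the scatter) from compound 1 to compound 2 and a 1.2-fold higher number (0.08 log units; within the scatter) from compound 3 to compound 4, 1.3-fold (0.12 log units) apart, within the scatter of two such steps. This shows that on these two cores the swap leaves the number within ordinary scatter, but it does not show that the same would hold on a third core, and the ring position of the new group also differs between the two pairs, so core and position cannot be told apart.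

The compounds shown leave open how groups other than methoxy and chloro would read at this place on the ring. An amine, a carboxylic acid or a longer chain such as butoxy could behave quite differently.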